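Methoxy Addition on a Thiazole Aryl Amide Series

The source may hold more compounds than are shown below. What is called first, only, known or untested is meant among the compounds shown, and "the series" means these compounds.

Compound 1 `Cc1cc(C(=O)c2ccc(F)cc2)ccc1OCC(=O)Nc1nc(-c2ccccc2)cs1` was tested in a functional assay on DLA cells (Mus musculus) for cytotoxicity, read by MTT assay, with a stated time of 48 h (a lower number here means a stronger inhibitor, a higher number a weaker inhibitor), where compound 1 gives 33300 nM. Compound 2 `Cc1cc(C(=O)c2ccccc2)cc(C)c1OCC(=O)Nc1nc(-c2ccccc2)cs1` differs from compound 1 by more than one part of the molecule; the difference between the two cores is not broken down here. In this assay compound 2 gives 19400 nM. Compound 3 `COc1ccc(-c2csc(NC(=O)COc3c(C)cc(C(=O)c4ccccc4)cc3C)n2)cc1` carries the change (methoxy in place of hydrogen on an aromatic carbon), and in this assay compound 3 gives 39400 nM. That change made the step of a 2.0-fold higher number from compound 2 to compound 3 (0.31 log units; beyond the scatter).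

Compound 4 `COc1ccc(-c2csc(NC(=O)COc3ccc(C(=O)c4ccc(F)cc4)cc3C)n2)cc1` has not yet been measured. It differs from compound 1 by methoxy in place of hydrogen on an aromatic carbon, the same change seen between compound 2 and compound 3, at the same place on the same kind of ring. Because the earlier step of a 2.0-fold higher number from compound 2 to compound 3 (0.31 log units; beyond the scatter) went toward a higher number, a step of similar size is expected here, estimated as a 2.0-fold higher number from compound 1 to compound 4 (0.29 log units; within the scatter). Compound 4 is therefore expected to give about 65000 nM in this assay, with the range 35000 nM to 120000 nM judged likely.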

Compound 4, half-maximal inhibitory concentration: 5400 nM
Beside the measured number, compound 4's estimate is 12-fold (1.08 log units) above it; the measured number lies below the stated range.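

In this assay, the change from phenyl to 4-methoxyphenyl gave a 6.2-fold lower number from compound 1 to compound 4 (0.79 log units; beyond the scatter). Set beside the earlier step, the same change did not carry over from one core to the other, in direction or in size: the same change on two cores in this assay, a 2.0-fold higher number (0.31 log units; beyond the scatter) from compound 2 to compound 3 and a 6.2-fold lower number (0.79 log units; beyond the scatter) from compound 1 to compound 4, 13-fold (1.10 log units) apart, beyond the scatter of two such steps. This shows that a step read on one core in this series could not be transferred to the other, but with a single pair on each core it does not show what in the cores separates the two results, nor how the change would run on a further core.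

The compounds shown leave open whether the fluorine on one core or the extra methyl on the other is tied to the opposite steps. They also leave open whether another group in place of the methoxy, such as a chlorine, a hydroxyl or an amine, would follow the same split between the two cores.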